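Aryl swap on the shared core: compound 3 expected

A few compounds are considered here, and "the series" means these few. Any claim that something is new, unique, unknown or untested is made for them only; others in the source may bear on it.

Compound 1 `N#CC1=C(N)Oc2c(c3nc4ccccc4nc3c3ccccc23)C12C(=O)N(Cc1cnnn1-c1ccc(Br)cc1)c1ccccc12` gives in an ADME assay on HUVEC cells (Homo sapiens) for antiproliferative activity, read by MTT assay, with a stated time of 48 h (on this read-out higher numbers stand for weaker inhibition and lower numbers for stronger inhibition), the limit > 50000 nM.
Compound 2 `CCOc1ccccc1-n1nncc1CN1C(=O)C2(C(C#N)=C(N)Oc3c2c2nc4ccccc4nc2c2ccccc32)c2ccccc21` gives in this assay the limit > 50000 nM.

Compound 2 therefore stands at the limit of this assay, with no number of its own. Among the compounds with values here, the only measured step, a step that the two limits leave unreadable from compound 1 to compound 2, is unreadable, since both of its ends are limits; this is summed up by the limit of > 50000 nM in this assay, at which 2 of the 2 values shown sit. Compound 3 `Cc1ccc(-n2nncc2CN2C(=O)C3(C(C#N)=C(N)Oc4c3c3nc5ccccc5nc3c3ccccc43)c3ccccc32)cc1C` has not yet been measured in this assay. It differs from compound 2 by 3,4-dimethylphenyl in place of 2-ethoxyphenyl on an aromatic nitrogen. Within the data shown here, no measured step bears readably on this change, because the step that the two limits leave unreadable from compound 1 to compound 2 gives no size. The expectation for compound 3 is that it again sits at the limit of this assay, so its value is estimated at 50000 nM within 20000 nM to 100000 nM. The step from compound 2 to compound 3 is accordingly expected to be a number no higher from compound 2 to compound 3 (the limit leaves the size open), nothing readable beyond the scatter.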

Compound 3, half-maximal inhibitory concentration: > 50000 nM
Compound 3: only a limit was reported; the forecaster's own chance of this, stated with the estimate: 80%; the middle value lies on the limit itself.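

Compound 3, like compound 1 and compound 2, gives only a limit in this assay, so no step among these three compounds can be read: the limit of > 50000 nM in this assay, at which 3 of the 3 values shown sit.
The compounds shown leave open whether 4-bromophenyl, 2-ethoxyphenyl and 3,4-dimethylphenyl on the aromatic nitrogen differ at all in this assay.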